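The source may report more compounds than this note shows. Statements on the series, on what has been measured and on what is new or still open speak of the compounds shown alone.

For the measured compounds named here, compound 2 `Nc1nc(-c2ncco2)nc2sc(Cc3ccccc3)cc12` is one of two compounds measured so far in a functional assay on CHO-K1 cells for antagonist activity at adenosine receptor A1 (Homo sapiens), read by a beta-galactosidase reporter and cAMP accumulation, with stated times of 15 min and 6 h; a lower number here means a stronger inhibitor, a higher number a weaker inhibitor: compound 2 gives 310 nM, and compound 1 `Cc1ccc(-c2nc(N)c3cc(Cc4ccccc4)sc3n2)o1` gives 298 nM, the step of a 1.0-fold higher number from compound 1 to compound 2 (0.02 log units; within the scatter) lying within the scatter. Compound 3 `Cn1cnc(-c2nc(N)c3cc(Cc4ccccc4)sc3n2)c1` differs from compound 2 by 1-methyl-1H-imidazol-4-yl in place of 1,3-oxazol-2-yl on an aromatic carbon. Going by the values given here, the one measured step bears on this change, since it also exchanged one five-membered aromatic ring with two hetero atoms for another and left this assay unchanged, so the expected step of a 1.0-fold higher number from compound 2 to compound 3 (0.01 log units; within the scatter) does not go beyond the scatter. Compound 3 is therefore estimated at 320 nM, between 150 nM and 700 nM.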

Compound 3, inhibition constant: 2330 nM
Estimate against measurement, compound 3: 7.3-fold (0.86 log units) below; the measured number lies above the stated range.
By their numbers in this assay, from the lowest: compounds 1 and 2 (each within the scatter of the next); then compound 3.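

In this assay, the position between two ring nitrogen atoms does not treat every five-membered aromatic ring with 2 hetero atoms alike: 1-methyl-1H-imidazol-4-yl gives a weaker inhibitor than 1,3-oxazol-2-yl (a 7.5-fold higher number from compound 2 to compound 3 (0.88 log units; beyond the scatter)) and than 5-methylfuran-2-yl (a 7.8-fold higher number from compound 1 to compound 3 (0.89 log units; beyond the scatter)). For the compounds shown here, compound 3 thus provides the first change at this position that goes beyond the scatter. Nothing available accounts for this step. The compounds shown leave open whether the step follows the ring or its methyl group, and where 1H-imidazol-4-yl or pyridin-2-yl would stand here.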